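From Trifluoromethyl to Methoxy on a Shared Core

The source may hold more compounds than are shown below. What is called first, only, known or untested is meant among the compounds shown, and "the series" means these compounds.

Within the data shown here, only two compounds of this family have numbers so far. In a functional assay on Jurkat cells (Homo sapiens) for antiproliferative activity, read by MTT assay, with a stated time of 72 h (a lower number here means a stronger inhibitor, a higher number a weaker inhibitor), compound 1 `COc1ccc(-c2sc(N(C)C)nc2-c2cc(OC)c(OC)c(OC)c2)cc1` gives 7600 nM and compound 2 `COc1cc(-c2nc(C)sc2-c2ccc(C(F)(F)F)cc2)cc(OC)c1OC` gives 7110 nM in the same test. Compound 2 therefore stands level with compound 1, as the two values lie within the usual scatter of repeated measurements. Compound 3 `COc1ccc(-c2sc(C)nc2-c2cc(OC)c(OC)c(OC)c2)cc1` is compound 2 with one change: methoxy in place of trifluoromethyl on an aromatic carbon, para to a large group methoxy in place of trifluoromethyl on an aromatic carbon and nothing else. Among the measured compounds shown here, no measured pair shows this change on its own, so what follows is a judgement with wide uncertainty. A move toward a stronger inhibitor in this assay seems likely, beyond the scatter. The expected size is a 24-fold lower number from compound 2 to compound 3 (1.37 log units; beyond the scatter) in that direction. For compound 3 the estimated value is 300 nM with an expected range from 15 nM to 5000 nM before any measurement.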

Compound 3, half-maximal inhibitory concentration: 1760 nM
Beside the measured number, compound 3's estimate is 5.9-fold (0.77 log units) below it; measured number inside the range.
By their numbers in this assay, from the lowest: compound 3; then compounds 2 and 1 (each within the scatter of the next).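

In this assay, methoxy in place of trifluoromethyl on an aromatic carbon, para to a large group, gives a 4.0-fold lower number from compound 2 to compound 3 (0.61 log units; beyond the scatter), so this position responds to a single change by more than the scatter. The second site responds as well: methyl in place of dimethylamino on an aromatic carbon gives a 4.3-fold lower number from compound 1 to compound 3 (0.64 log units; beyond the scatter), so each of these two one-place changes leads to compound 3 with a modest drop in the number. Nothing measured here gives a reason for either step.

Going by these compounds, each site has so far been seen with only these groups, so the shape of the trend at either one remains unknown. On these data alone, whether a chlorine atom or an ethoxy group in place of the methoxy, or a primary amine or an ethyl chain in place of the methyl, would lower the number further remains open.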